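Compound 2 and its 2-hydroxyethyl relative, compound 3

The source may hold more compounds than are shown below. What is called first, only, known or untested is meant among the compounds shown, and "the series" means these compounds.

compound 1 `C=CCc1ccc(OCc2cn(-c3cccc([N+](=O)[O-])c3)nn2)c(O)c1` gives 42.3%
compound 2 `C=CCc1cc(O)c(O)c(CN2CCC(C)CC2)c1` gives 41.7%

Both numbers come from a functional assay on MCF7 cells (Homo sapiens) for inhibition, read by MTT assay, with a stated time of 72 h, tested at 30 uM (on this read-out higher numbers stand for more inhibition of growth at the one concentration tested and lower numbers for less inhibition of growth), and lie within the usual scatter of each other, so compound 2 cannot be told apart from compound 1 on this evidence. For the measured compounds named here, the two compounds also differ in more than one place, so they offer no measured step to learn from.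

Compound 3 `C=CCc1cc(O)c(O)c(CN2CCC(CCO)CC2)c1` has not been measured yet. It differs from compound 2 in one place: hydroxymethyl in place of hydrogen on a saturated chain carbon bound to a saturated ring carbon. Cut one bond further out, the same difference reads methyl to 2-hydroxyethyl.

Going by the values given here, no measured step shows what this kind of change does in this assay so a large move has no support in the data. The natural starting point is compound 2 (41.7%) and only a slight drop is expected from there. The expected step is a number 3.7 percentage points lower from compound 2 to compound 3 (within the scatter) and it stays inside the usual scatter. The estimate for compound 3 is 38% with an expected range from 24% to 52% in this measurement.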

Compound 3, percent growth inhibition at one concentration: 21.4%
Compound 3: the middle estimate sits 16.6 percentage points above what was measured; the whole stated range lies above it.
By their numbers in this assay, from the lowest: compound 3; then compounds 2 and 1 (each within the scatter of the next).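

For the compounds shown here, the change from methyl to 2-hydroxyethyl gives the first measured step in this set, and in this assay it reads a number 20.3 percentage points lower from compound 2 to compound 3 (beyond the scatter) for inhibition of growth. This shows that the position, a saturated chain carbon bound to a saturated ring carbon, is not indifferent to what it carries: hydroxymethyl in place of hydrogen, a group of only 2 heavy atoms, is enough to produce a clear change in the number. Nothing measured on these compounds explains the drop, so the step stands as an observation without a known cause.

A single step cannot separate the added chain length from the hydroxyl at its end, and a plain ethyl or propyl group at this place would be needed to tell the two apart. Going by these compounds, it also stays open whether a 2-methoxyethyl group, an amine or a carboxylic acid on the same chain would read like compound 2 or like compound 3, and whether the same change would do the same on another core.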